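One methoxy fewer on the trimethoxyphenyl analogue

The source may hold more compounds than are shown below. What is called first, only, known or untested is meant among the compounds shown, and "the series" means these compounds.

In a functional assay on HCT-116 cells (Homo sapiens) for antiproliferative activity, read by MTT assay, with a stated time of 48 h (a lower number here means a stronger inhibitor, a higher number a weaker inhibitor), compound 1 (`COc1ccc(CN(C(=O)CSc2nc3ccccc3s2)c2cc(OC)c(OC)c(OC)c2)cc1`) gives 426 nM and compound 2 (`COc1cc(CN(C(=O)CSc2nc3ccccc3s2)c2cc(OC)c(OC)c(OC)c2)cc(OC)c1OC`) gives 65300 nM as the higher of the two numbers. Compound 3 (`COc1ccc(CN(C(=O)CSc2nc3ccccc3s2)c2cc(OC)c(OC)c(OC)c2)cc1OC`) carries 3,4-dimethoxyphenyl instead of the 3,4,5-trimethoxyphenyl of compound 2, with hydrogen in place of methoxy on an aromatic carbon. Within the data shown here, the one measured step that bears on this (a 150-fold higher number from compound 1 to compound 2 (2.19 log units; beyond the scatter)) is large and runs from 4-methoxyphenyl to 3,4,5-trimethoxyphenyl. Part of that step should be recovered, so a sizeable drop in this assay is expected (a 16-fold lower number from compound 2 to compound 3 (1.21 log units; beyond the scatter)). Compound 3 is estimated at 4000 nM within a range of 500 nM to 40000 nM as expected values.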

Compound 3, half-maximal inhibitory concentration: 33900 nM
Compound 3: the middle estimate sits 8.5-fold (0.93 log units) below what was measured; low and high end bracket the measured number.
By their numbers in this assay, from the lowest: compound 1; then compounds 3 and 2 (each within the scatter of the next).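

In this assay, taking away this methoxy from the 3,4,5-trimethoxyphenyl group regains nothing that can be told from scatter: a 1.9-fold lower number from compound 2 to compound 3 (0.28 log units; within the scatter). The large loss is already present with the single extra methoxy of the 3,4-dimethoxyphenyl group: an 80-fold higher number from compound 1 to compound 3 (1.90 log units; beyond the scatter). No supporting evidence bears on why this is so.

Still open, from the compounds shown here alone, is whether the loss belongs to methoxy itself or to any group on this aromatic carbon. A hydroxyl or an amine there could either share the number of compound 3 or stay with that of compound 1.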